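A few compounds are considered here, and "the series" means these few. Any claim that something is new, unique, unknown or untested is made for them only; others in the source may bear on it.

Compound 1 `CCN(CC)S(=O)(=O)c1ccc(S(=O)(=O)N2CCC[C@@H](C(=O)N[C@H]3CC[C@H](OC)CC3)C2)cc1` is the weakest of the three compounds measured in a functional assay on MIA PaCa-2 cells (Homo sapiens) for inhibition, read by MTT assay, with a stated time of 3 days (a lower number here means a stronger inhibitor, a higher number a weaker inhibitor), where compound 1 gives 2290 nM. Compound 2 `CCN(CC)S(=O)(=O)c1ccc(S(=O)(=O)N2CCC[C@@H](C(=O)N3CCC(C(F)(F)F)CC3)C2)cc1` gives 110 nM and compound 3 `CCN(CC)S(=O)(=O)c1ccc(S(=O)(=O)N2CCC[C@@H](C(=O)N3CC[C@@H](OC)C3)C2)cc1` gives 1070 nM in this assay. Compound 4 `CCN(CC)S(=O)(=O)c1ccc(S(=O)(=O)N2CCC[C@@H](C(=O)N[C@H]3CCOC3)C2)cc1` differs from compound 1 only at the amide end: oxolan-3-yl in place of 4-methoxycyclohexyl on an amide-type nitrogen.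

Among the compounds with values here, two measured steps bear on this change, both of them replacing the (4-methoxycyclohexyl)amino group on the carbonyl carbon. The step of a 21-fold lower number from compound 1 to compound 2 (1.32 log units; beyond the scatter) was large, and the step of a 2.1-fold lower number from compound 1 to compound 3 (0.33 log units; beyond the scatter) was modest. Both removed the amide hydrogen as well, which compound 4 keeps, so neither is a close model. Both, however, moved to a lower number, and the more modest of them, to the small methoxy-bearing ring, is the nearer analogy. The account therefore expects a small step in this assay toward a lower number, a 1.5-fold lower number from compound 1 to compound 4 (0.18 log units; within the scatter), which may not exceed the scatter. Compound 4 is estimated at 1500 nM, within a range from 500 nM to 5000 nM.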

Compound 4, half-maximal inhibitory concentration: 290 nM
Compound 4: middle estimate off by 5.2-fold (0.71 log units), on the high side, and the stated range ends above it.
By their numbers in this assay, from the lowest: compound 2; then compound 4; then compound 3; then compound 1.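

With the amide hydrogen kept, the change on the amide-type nitrogen alone gives a 7.9-fold lower number from compound 1 to compound 4 (0.90 log units; beyond the scatter) in this assay, so a much lower number at this position does not require losing that hydrogen. The oxolan-3-yl amide also stands clearly ahead of the other small oxygen-bearing ring, with a 3.7-fold lower number from compound 3 to compound 4 (0.57 log units; beyond the scatter), showing that a methoxy-bearing ring on the carbonyl carbon does not set the level for small rings here. Even so, the 4-(trifluoromethyl)piperidin-1-yl amide keeps the lowest number of the four, with a 2.6-fold higher number from compound 2 to compound 4 (0.42 log units; beyond the scatter).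

Nothing available explains these steps. As far as these compounds go, it remains open how an unsubstituted cyclohexyl or an oxan-4-yl group on the same amide-type nitrogen would read, which would help separate the size of the ring from the presence and placing of its oxygen.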